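Ester Variation on a Shared Core: Expecting Compound 3

The source may report more compounds than this note shows. Statements on the series, on what has been measured and on what is new or still open speak of the compounds shown alone.

Compound 1, `CC1=C(C(=O)CC(C)C)C(c2cccs2)NC(=O)N1`: 19%
Compound 2, `CCC(CC)OC(=O)C1=C(C)NC(=O)NC1c1cccs1`: 13%

For the measured compounds named here, in an assay on membranes from CHO cells for displacement of a labelled ligand from adenosine receptor A1 (Homo sapiens), read by scintillation counting, with a stated time of 60 min, tested at 1 uM (on this read-out higher numbers stand for more inhibition at the one concentration tested (going by the name of the read-out) and lower numbers for less inhibition), compound 2 stands alongside compound 1, the only measured step being a number 6 percentage points lower from compound 1 to compound 2 (within the scatter), which lies within the scatter. Compound 3, `CC1=C(C(=O)OC2CCC2)C(c2cccs2)NC(=O)N1`, differs from compound 2 by cyclobutyl in place of pentan-3-yl on an oxygen next to a carbonyl group. Going by the values given here, the one step that bears on it exchanged a group on the same carbonyl carbon and moved the number only a little, so no change beyond the scatter is expected for this smaller exchange. The expected step of a number 2 percentage points higher from compound 2 to compound 3 (within the scatter) is accordingly modest. Compound 3 is estimated at 15%, within 3% to 30%.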

Compound 3, a percentage reported as inhibition, at one concentration (the size of the read-out at that concentration, not a potency): 24%
For compound 3 the middle estimate is 9 percentage points below the measured one, and the stated range covers the measured number.
By their numbers in this assay, from the lowest: compounds 2, 1 and 3 (each within the scatter of the next, the first and the last beyond it).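

In this assay, cyclobutyl in place of pentan-3-yl on an oxygen next to a carbonyl group gives a number 11 percentage points higher from compound 2 to compound 3 (beyond the scatter), the only step shown that lies beyond the scatter. Cyclobutyloxy in place of isobutyl on a carbonyl carbon gives a number 5 percentage points higher from compound 1 to compound 3 (within the scatter), so this change does not set compound 3 apart from compound 1. Nothing available accounts for either step. The compounds shown leave open how a cyclopentyl or cyclohexyl ring on this oxygen would read, and what a carboxylic acid or an amide in place of the ester would do.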